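A few compounds are considered here, and "the series" means these few. Any claim that something is new, unique, unknown or untested is made for them only; others in the source may bear on it.

Among the compounds with values here, in an ADME assay on BJ cells (Homo sapiens) for cytotoxicity, read by MTT assay, with a stated time of 72 h (on this read-out higher numbers stand for lower toxicity in this test and lower numbers for higher toxicity in this test), compound 3 (`OC[C@H]1O[C@@H](n2cc(F)c3c(-c4ccc[nH]4)ncnc32)[C@H](O)[C@@H]1O`) gives 2990 nM, the highest of the three numbers so far, with compound 1 (`OC[C@H]1O[C@@H](n2cc(F)c3c(-c4ccco4)ncnc32)[C@H](O)[C@@H]1O`) at 310 nM and compound 2 (`OC[C@H]1O[C@@H](n2cc(F)c3c(-c4ccoc4)ncnc32)[C@H](O)[C@@H]1O`) at 350 nM. Compound 4 (`OC[C@H]1O[C@@H](n2cc(F)c3c(-c4cc[nH]c4)ncnc32)[C@H](O)[C@@H]1O`) carries 1H-pyrrol-3-yl in place of 1H-pyrrol-2-yl on an aromatic carbon. Within the data shown here, the closest precedent is the matching change among the furans, a 1.1-fold higher number from compound 1 to compound 2 (0.05 log units; within the scatter), which lies within the scatter. The larger steps, a 9.6-fold higher number from compound 1 to compound 3 (0.98 log units; beyond the scatter) and an 8.5-fold higher number from compound 2 to compound 3 (0.93 log units; beyond the scatter), exchange a furan for a pyrrole, a change not made here. No step beyond the scatter is therefore expected in this assay, although this rests on a single pair. The expected step is a 1.5-fold lower number from compound 3 to compound 4 (0.17 log units; within the scatter). The estimated value for compound 4 is 2000 nM, with an expected range of 600 nM to 6000 nM.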

Compound 4, half-maximal cytotoxic concentration: 2020 nM
Compound 4: middle estimate off by 1.0-fold (0.00 log units), on the low side; the range from low to high includes it.
By their numbers in this assay, from the lowest: compounds 1 and 2 (each within the scatter of the next); then compounds 4 and 3 (each within the scatter of the next).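

In this assay the step from 1H-pyrrol-2-yl to 1H-pyrrol-3-yl is a 1.5-fold lower number from compound 3 to compound 4 (0.17 log units; within the scatter) and stays within the scatter, so the point of attachment at this carbon shows no clear effect among the pyrroles either. The separation from the furans no longer rests on compound 3 alone, since the 1H-pyrrol-3-yl group gives a 5.8-fold higher number from compound 2 to compound 4 (0.76 log units; beyond the scatter) and a 6.5-fold higher number from compound 1 to compound 4 (0.81 log units; beyond the scatter) in the same direction. No measurement at hand bears on why the pyrroles and furans differ. Still open, as far as these compounds go, is where a thiophene, a phenyl ring or an amine at this carbon would fall relative to these two pairs.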